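A methylated pyrazole on the second arm

This account rests on a few compounds, and the source may have more. Where it says the series, first, only, none or still open, it means among the compounds named here.

Three ureas built on one shared core have been tested in a functional assay on a cell-free system (plasma) with sterol O-acyltransferase, Soat (Rattus norvegicus) as the target; a lower number here means that less compound is needed, a higher number that more compound is needed for the effect. Compound 1 `Cc1cc(C)c(NC(=O)N(Cc2ccc(-c3cn[nH]c3)cc2)C2CCCCCC2)c(C)c1` carries a 1H-pyrazol-4-yl group para to a large group. In this assay compound 1 gives > 1 mg/kg, which is a limit of the assay and not a number. Compound 2 `Cc1cc(C)c(NC(=O)N(Cc2cccc(-c3cn[nH]c3)c2)C2CCCCCC2)c(C)c1` has the same atoms joined differently; the difference between the two cores is not broken down here. In this assay compound 2 gives 0.19 mg/kg. Compound 3 `Cc1cc(C)c(NC(=O)N(Cc2ccc(-c3ccn(C)n3)cc2)C2CCCCCC2)c(C)c1` differs from compound 1 in this way: 1-methyl-1H-pyrazol-3-yl in place of 1H-pyrazol-4-yl on an aromatic carbon. In this assay compound 3 gives < 1 mg/kg, again a limit. The step measured is a number no higher from compound 1 to compound 3 (the limit leaves the size open), with the two ends resting on the limit of > 1 mg/kg in this assay, at which 1 of the 3 values shown sits, and (the limit of < 1 mg/kg in this assay, at which 1 of the 3 values shown sits).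

Compound 4 `Cc1cc(C)c(NC(=O)N(Cc2cccc(-c3ccn(C)n3)c2)C2CCCCCC2)c(C)c1` has not been measured. It differs from compound 2 in this way: 1-methyl-1H-pyrazol-3-yl in place of 1H-pyrazol-4-yl on an aromatic carbon. This is the same kind of change as that from compound 1 to compound 3, but the place is not the same: para to a large group there, meta to a large group here.

In this assay the expected step is a 1.3-fold lower number from compound 2 to compound 4 (0.10 log units; within the scatter), resting on the open-sized finding of a number no higher from compound 1 to compound 3 (the limit leaves the size open). In this assay compound 4 is expected to give 0.15 mg/kg, estimated to fall between 0.05 mg/kg and 0.5 mg/kg.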

Compound 4, dose for half-maximal effect: < 1 mg/kg
Compound 4 gave a limit, no number; the forecaster's own chance of this, stated with the estimate: 10%; the middle value lies beyond the limit too.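

In this assay, among the compounds shown here, compound 4 gives < 1 mg/kg, which is a limit of the assay and not a number, so no step between compound 2 and compound 4 can be read. The compounds shown leave open whether 1-methyl-1H-pyrazol-3-yl in place of 1H-pyrazol-4-yl, meta to a large group, changes the number at all, and by how much.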